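The compounds below may be only part of what the source reports. "The series", "measured", "known", "first", "only" and "open" are said of these compounds alone.

Measured compounds:
compound 1 `CCCn1c(=O)c2nc(-c3cnn(Cc4c(F)cccc4F)c3)[nH]c2n(CCC)c1=O` — 390 nM
compound 2 `CC(C)Cn1c(=O)c2nc(-c3cnn(Cc4cccc(F)c4)c3)[nH]c2n(CC(C)C)c1=O` — 990 nM

Both compounds were tested in an in vitro assay on HEK293 cells for displacement of a labelled ligand from adenosine receptor A2b (Homo sapiens); a higher number here means a weaker inhibitor, a lower number a stronger inhibitor. Compound 1 gives 390 nM, and compound 2 gives 990 nM. Of these two numbers, compound 1 has the lower one, and the gap between them is wider than the usual spread between repeated measurements, so on what has been measured compound 1 is the stronger binder of the pair. The two compounds differ in more than one place, so no single structural change can be tied to that gap.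

Compound 3 `CCCn1c(=O)c2nc(-c3cnn(Cc4ccccc4C)c3)[nH]c2n(CCC)c1=O` has not yet been measured. It differs from compound 1 in one place: 2-methylphenyl in place of 2,6-difluorophenyl on a saturated chain carbon bound to an aromatic nitrogen. For the measured compounds named here, nothing among the measured compounds shows what this particular change does, so the expectation rests on the general observation that altering this benzyl group shifts the numbers by a moderate amount. A small weakening is expected, with the step of a 1.5-fold higher number from compound 1 to compound 3 (0.19 log units; within the scatter) likely not far beyond the scatter in either direction. Compound 3 is therefore estimated at 600 nM in this assay, within a range from 200 nM to 1800 nM.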

Compound 3, inhibition constant: 33 nM
The estimate for compound 3 lay 18-fold (1.26 log units) above the measured number; measured number outside the range, below it.
By their numbers in this assay, from the lowest: compound 3; then compound 1; then compound 2.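

In this assay, putting 2-methylphenyl in place of 2,6-difluorophenyl on a saturated chain carbon bound to an aromatic nitrogen, with the rest of the molecule left as it is, gives a 12-fold lower number from compound 1 to compound 3 (1.07 log units; beyond the scatter) and shows that the group at this place matters a great deal for binding. For the compounds shown here, compound 1 and compound 2 could not show this, as they differ in more than one place and their gap cannot be tied to any single part of the structure; here, for the first time, one change can be read on its own, and it is a large one. No measurement shown here explains why the 2-methylphenyl compound gives the lower number.

The change removes two fluorine atoms and brings in a methyl group in a single step, so the compounds shown cannot tell whether losing the fluorines, gaining the methyl or both together produce the step, and a plain unsubstituted phenyl group would help to separate these. As far as these compounds go, it also remains open how far this benzyl group can be varied, for instance whether a 2-ethylphenyl, 2-chlorophenyl or 2-methoxyphenyl group in the same place would lower the number further or raise it again.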